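Thiophen-2-yl in place of phenyl on the shared core

The source may report more compounds than this note shows. Statements on the series, on what has been measured and on what is new or still open speak of the compounds shown alone.

Within the data shown here, in a functional assay on HT-29 cells (Homo sapiens) for inhibition, read by MTT assay, with a stated time of 48 h (a higher number here means a weaker inhibitor, a lower number a stronger inhibitor), compound 2 (`COc1cc(-c2cc(-c3ccccc3)nc(-c3ccccc3)n2)cc(OC)c1OC`) gives 7930 nM and compound 1 (`COc1cc(-c2cc(-c3ccc(Cl)cc3)nc(-c3ccccc3)n2)cc(OC)c1OC`) gives 6230 nM within the scatter of each other, so compound 2 stands level with its only measured neighbour. Compound 3 (`COc1cc(-c2cc(-c3cccs3)nc(-c3ccccc3)n2)cc(OC)c1OC`) carries thiophen-2-yl in place of phenyl on an aromatic carbon next to the ring nitrogen (thiophen-2-yl in place of phenyl on an aromatic carbon). Among the measured compounds shown here, the one measured step, a 1.3-fold higher number from compound 1 to compound 2 (0.10 log units; within the scatter) for hydrogen in place of chloro on an aromatic carbon, stays within the scatter, so no step beyond the scatter is expected in this assay for this change. The estimate means a 1.1-fold lower number from compound 2 to compound 3 (0.05 log units; within the scatter) as the expected step. Compound 3 is estimated at 7000 nM with an expected range from 3000 nM to 16000 nM in this series.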

Compound 3, half-maximal inhibitory concentration: > 25000 nM
Compound 3: a limit, no number (the forecaster's own chance of this, stated with the estimate: 5%); middle value at least 3.5-fold (0.55 log units) from the limit.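

Compound 3 is a limit, not a number: the limit of > 25000 nM in this assay, at which 1 of the 3 values shown sits. In this assay, this position, on an aromatic carbon next to the ring nitrogen, proves sensitive to the ring it carries: thiophen-2-yl in place of phenyl gives an at least 3.1-fold higher number from compound 2 to compound 3 (0.49 log units; beyond the scatter), and thiophen-2-yl in place of 4-chlorophenyl gives an at least 4.0-fold higher number from compound 1 to compound 3 (0.60 log units; beyond the scatter). The earlier change on the phenyl ring itself stayed small, at a 1.3-fold higher number from compound 1 to compound 2 (0.10 log units; within the scatter).

On these data alone, the true size of both steps stays open, since they rest on a limit. Also open, as far as these compounds go, is whether a pyridinyl ring or an amine-bearing phenyl at this position would hold the level of compound 2.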